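This account rests on a few compounds, and the source may have more. Where it says the series, first, only, none or still open, it means among the compounds named here.

Compound 3 `CCNC(=O)Nc1ccc2c(cnn2CC(=O)COc2ccc(Oc3ccccc3)cc2)c1` gives 1600 nM in an assay on microsomes from brain for inhibition of Fatty-acid amide hydrolase 1 (Rattus norvegicus), read by fluorescence and HPLC, with a stated time of 45 min (a higher number here means a weaker inhibitor, a lower number a stronger inhibitor), the second highest of the three numbers measured: compound 1 `CC(=O)Nc1ccc2c(cnn2CC(=O)COc2ccc(Oc3ccccc3)cc2)c1` gives 3900 nM and compound 2 `O=C(COc1ccc(Oc2ccccc2)cc1)Cn1ncc2cc([N+](=O)[O-])ccc21` gives 550 nM. Compound 4 `O=C(COc1ccc(Oc2ccccc2)cc1)Cn1ncc2cc(C(=O)NS(=O)(=O)C(F)(F)F)ccc21` carries ((trifluoromethyl)sulfonyl)carbamoyl in place of (ethylcarbamoyl)amino on an aromatic carbon. Going by the values given here, two measured steps bear on exchanges at this same aromatic carbon: a 2.4-fold lower number from compound 1 to compound 3 (0.39 log units; beyond the scatter) and a 2.9-fold higher number from compound 2 to compound 3 (0.46 log units; beyond the scatter). Both were modest, and the nitro of compound 2 gave the lowest number of the three. A further exchange at that carbon is therefore expected to shift this assay only modestly, most likely toward a lower number, so that a 2.0-fold lower number from compound 3 to compound 4 (0.30 log units; within the scatter) is the estimated step. For compound 4 the expected value is 800 nM, with a range from 250 nM to 2500 nM.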

Compound 4, half-maximal inhibitory concentration: 510 nM
For compound 4 the middle estimate is 1.6-fold (0.20 log units) above the measured one; the range from low to high includes it.
By their numbers in this assay, from the lowest: compounds 4 and 2 (each within the scatter of the next); then compound 3; then compound 1.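

In this assay this aromatic carbon takes the larger ((trifluoromethyl)sulfonyl)carbamoyl without loss, giving a 3.1-fold lower number from compound 3 to compound 4 (0.50 log units; beyond the scatter) and a 7.6-fold lower number from compound 1 to compound 4 (0.88 log units; beyond the scatter) as modest gains over the two amide-type groups. The new result also shows that the nitro is not alone in reaching this level: a 1.1-fold lower number from compound 2 to compound 4 (0.03 log units; within the scatter) leaves the two groups indistinguishable despite their different atoms. No evidence here accounts for this. Still open, as far as these compounds go, is how a carboxylic acid or a simple amine on this carbon would compare, and whether a longer chain on the carbamoyl nitrogen would change the number.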